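Series notes: the step from compound 2 to compound 3

The source may report more compounds than this note shows. Statements on the series, on what has been measured and on what is new or still open speak of the compounds shown alone.

Of the compounds shown here, two have been read so far in an ADME assay on HEK-293T cells (Homo sapiens) for cytotoxicity, read by CCK-8 assay, with a stated time of 48 h (a higher number here means a weaker inhibitor, a lower number a stronger inhibitor), on this series. Compound 1 (`O=C(NCCNS(=O)(=O)c1ccc(-c2ccccc2Oc2ccc([N+](=O)[O-])c([N+](=O)[O-])c2)s1)Nc1cc(Cl)cc(Cl)c1`) gives > 20000 nM as a limit and not a number. Compound 2 (`Cc1ccc(-c2ccsc2S(=O)(=O)NCCNC(=S)Nc2ccc([N+](=O)[O-])cc2)c(Oc2ccc(O)c(O)c2)c1`) gives 8200 nM as the only actual number shown. Compound 3 (`Cc1ccc(-c2ccsc2S(=O)(=O)NCCNC(=O)Nc2cccc([N+](=O)[O-])c2)c(Oc2ccc(O)c(O)c2)c1`) is still unmeasured and differs from compound 2 in one place, on an amine nitrogen whose other neighbour is a saturated chain carbon: a group of 12 heavy atoms (7 carbon, 2 nitrogen, 3 oxygen; one six-membered aromatic ring of carbon only) in place of a group of 12 heavy atoms (7 carbon, 2 nitrogen, 2 oxygen, 1 sulfur; one six-membered aromatic ring of carbon only), on an amine nitrogen gives the count for the swap, with (3-nitrophenyl)carbamoyl entering. No measured step sizes this change, so the expectation rests on compound 2 at 8200 nM alone: a slight move toward a higher number in this assay and no larger than the scatter. The expected change a 1.5-fold higher number from compound 2 to compound 3 (0.17 log units; within the scatter) is therefore small. The estimated value for compound 3 is 12000 nM with an expected range from 5000 nM to 22000 nM as its bounds.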

Compound 3, half-maximal inhibitory concentration: 6800 nM
Compound 3: the middle estimate sits 1.8-fold (0.25 log units) above what was measured; measured number inside the range.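

In this assay, the first step read at this amine nitrogen is a 1.2-fold lower number from compound 2 to compound 3 (0.08 log units; within the scatter). With (3-nitrophenyl)carbamoyl in place of the sulfur-bearing group of equal heavy-atom count, the swap taken as a whole does not separate compound 2 from compound 3, and the series now has two actual numbers on the shared core where it had one. Compound 1 remains a limit and not a number, so it sizes nothing at this position: the limit of > 20000 nM in this assay, at which 1 of the 3 values shown sits.

The step carries the oxygen for sulfur exchange and the change of nitrophenyl group together, and the compounds shown do not read either part alone. On these data alone, how a carboxylic acid in place of the nitro group, or a longer chain on this amine nitrogen, would read in this assay remains open.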